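Coumarin-piperidine series: nitrooxymethyl benzyl analogue, expected inhibition

The source may hold more compounds than are shown below. What is called first, only, known or untested is meant among the compounds shown, and "the series" means these compounds.

Measured compounds:
compound 1 `CN(C)Cc1ccc(COc2ccc3c(CO)cc(=O)oc3c2)cc1`, 78 nM
compound 2 `Cc1c(C)c2ccc(OCC3CCN(Cc4ccc(CO)cc4)CC3)cc2oc1=O`, 29 nM
compound 3 `Cc1c(C)c2ccc(OCC3CCN(Cc4ccc(CCO)cc4)CC3)cc2oc1=O`, 120 nM

In an assay for inhibition of Amine oxidase [flavin-containing] B (Homo sapiens), read by fluorescence, using microsomes, with a stated time of 30 min (on this read-out higher numbers stand for weaker inhibition and lower numbers for stronger inhibition), compound 3 gives the highest number of the three. Compound 1 sits within the scatter of it; compound 2 lies clearly lower, as the step of a 4.1-fold higher number from compound 2 to compound 3 (0.62 log units; beyond the scatter) shows.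

Compound 4 `Cc1c(C)c2ccc(OCC3CCN(Cc4cccc(CO[N+](=O)[O-])c4)CC3)cc2oc1=O` differs from compound 3 by 3-((nitrooxy)methyl)phenyl in place of 4-(2-hydroxyethyl)phenyl on a saturated chain carbon bound to an amine nitrogen in a ring. Within the data shown here, no measured pair covers a nitrooxy group or this ring substitution pattern; the only step touching the benzyl substituent is a 4.1-fold higher number from compound 2 to compound 3 (0.62 log units; beyond the scatter), which is modest. The change is therefore expected to move this assay by no more than a modest amount, direction uncertain, with some lean toward a lower number given that compound 3 already holds the highest value.

Compound 4 is estimated at 70 nM, range 20 nM to 250 nM, a step of a 1.7-fold lower number from compound 3 to compound 4 (0.23 log units; within the scatter).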

Compound 4, half-maximal inhibitory concentration: 51 nM
The estimate for compound 4 lay 1.4-fold (0.14 log units) above the measured number; the range from low to high includes it.
By their numbers in this assay, from the lowest: compounds 2, 4, 1 and 3 (each within the scatter of the next, the first and the last beyond it).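

Against the hydroxy-bearing benzyl groups, this assay gives a 2.4-fold lower number from compound 3 to compound 4 (0.37 log units; beyond the scatter) and a 1.8-fold higher number from compound 2 to compound 4 (0.25 log units; within the scatter). The place on a saturated chain carbon bound to an amine nitrogen in a ring therefore accepts 3-((nitrooxy)methyl)phenyl, a group with 0 hydrogen-bond donors, with no loss against compound 3 and a difference from compound 2 that stays within the scatter. No supporting evidence bears on the reason for either step.

The compounds shown change the group and its ring placement together, leaving their separate contributions open. From the compounds shown here alone, how a phenyl bearing a carboxylic acid would read in this place also remains open.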